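Trifluoromethyl in place of methoxy: what to expect

This account rests on a few compounds, and the source may have more. Where it says the series, first, only, none or still open, it means among the compounds named here.

Among the measured compounds shown here, in an ADME assay on cells (Macrophage, Homo sapiens) for cytotoxicity, read by microscopy and MTT assay, with a stated time of 24 h (on this read-out lower numbers stand for higher toxicity in this test and higher numbers for lower toxicity in this test), compound 1 `Cc1ncc([N+](=O)[O-])n1CCOc1ccc(/C=N/Nc2nc(-c3ccccc3)cs2)cc1` gives 467 ug/mL as its reading, and compound 2 `COc1ccc(-c2csc(N/N=C/c3ccc(OCCn4c([N+](=O)[O-])cnc4C)cc3)n2)cc1` gives 268 ug/mL as its reading, so compound 2 stands within the usual scatter of the only other measured compound. The next compound, compound 3 `Cc1ncc([N+](=O)[O-])n1CCOc1ccc(/C=N/Nc2nc(-c3ccc(C(F)(F)F)cc3)cs2)cc1`, has not yet been measured. It carries trifluoromethyl in place of methoxy on an aromatic carbon, para to a large group (trifluoromethyl in place of methoxy on an aromatic carbon). For the measured compounds named here, only one measured step bears on this change: a 1.7-fold lower number from compound 1 to compound 2 (0.24 log units; within the scatter) for methoxy in place of hydrogen on an aromatic carbon. Going by the values given here, no compound measured so far carries trifluoromethyl, so the data give no direction for the swap. The step expected is therefore a 1.1-fold higher number from compound 2 to compound 3 (0.05 log units; within the scatter) and no shift beyond the scatter is expected. For compound 3 the estimated reading is 300 ug/mL with an expected range from 130 ug/mL to 650 ug/mL in this test.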

Compound 3, half-maximal cytotoxic concentration: 218 ug/mL
Estimate against measurement, compound 3: 1.4-fold (0.14 log units) above; the measured number falls inside the stated range.
By their numbers in this assay, from the lowest: compounds 3, 2 and 1 (each within the scatter of the next, the first and the last beyond it).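

In this assay the swap of methoxy for trifluoromethyl on this aromatic carbon, para to a large group, gives a 1.2-fold lower number from compound 2 to compound 3 (0.09 log units; within the scatter) and so does not separate the two groups in this test. Trifluoromethyl in place of hydrogen on the same carbon gives a 2.1-fold lower number from compound 1 to compound 3 (0.33 log units; beyond the scatter) and is the only step among these compounds to pass the scatter, though only modestly, whereas methoxy in place of hydrogen gives a 1.7-fold lower number from compound 1 to compound 2 (0.24 log units; within the scatter) and does not pass it. Nothing measured alongside these readings bears on why the number moves. On these data alone, whether an amine or a carboxylic acid on this same aromatic carbon would lift the number or lower it stays open. So does whether trifluoromethyl would give a similar step on a different carbon of that ring.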